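This account rests on a few compounds, and the source may have more. Where it says the series, first, only, none or still open, it means among the compounds named here.

Of the compounds shown here, three built on one shared core have been measured in an assay on LtK cells with ATP-sensitive inward rectifier potassium channel 11 (Homo sapiens) as the target; on this read-out lower numbers stand for an effect already at smaller amounts and higher numbers for an effect only at larger amounts of compound. Compound 1 `CCCC(=O)Nc1c(C(O)(C(F)(F)F)C(F)(F)F)ccc2ccccc12` gives 131 nM; compound 2 `CCC(C)C(=O)Nc1c(C(O)(C(F)(F)F)C(F)(F)F)ccc2ccccc12` gives 177000 nM; compound 3 `O=C(Nc1c(C(O)(C(F)(F)F)C(F)(F)F)ccc2ccccc12)c1ccccc1Cl` gives 2040 nM, the second highest of the three numbers. The measured steps are a 1400-fold higher number from compound 1 to compound 2 (3.13 log units; beyond the scatter), a 16-fold higher number from compound 1 to compound 3 (1.19 log units; beyond the scatter) and an 87-fold lower number from compound 2 to compound 3 (1.94 log units; beyond the scatter). Compound 4 `O=C(Nc1c(C(O)(C(F)(F)F)C(F)(F)F)ccc2ccccc12)c1ccc(I)cc1` differs from compound 3 in one place: 4-iodophenyl in place of 2-chlorophenyl on a carbonyl carbon. Among the measured compounds shown here, no measured step exchanges one aromatic ring for another on the carbonyl carbon; the two steps that alter this group, a 16-fold higher number from compound 1 to compound 3 (1.19 log units; beyond the scatter) and an 87-fold lower number from compound 2 to compound 3 (1.94 log units; beyond the scatter), only show that changes here can move this assay strongly. A modest step in either direction is therefore expected, and the estimate means a 1.0-fold lower number from compound 3 to compound 4 (0.01 log units; within the scatter). Compound 4 is estimated at 2000 nM, in the range from 400 nM to 10000 nM.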

Compound 4, half-maximal effective concentration: 154 nM
Compound 4: the middle estimate sits 13-fold (1.11 log units) above what was measured, outside the stated range (below it).
By their numbers in this assay, from the lowest: compounds 1 and 4 (each within the scatter of the next); then compound 3; then compound 2.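

In this assay, among the compounds shown here, this is the first exchange of one aromatic ring for another on the carbonyl carbon: 4-iodophenyl in place of 2-chlorophenyl gives a 13-fold lower number from compound 3 to compound 4 (1.12 log units; beyond the scatter), so the ring's substitution matters, not only ring versus chain. An aromatic ring can also read like the propyl chain, with a 1.2-fold higher number from compound 1 to compound 4 (0.07 log units; within the scatter), while the sec-butyl compound lies far away, with a 1100-fold lower number from compound 2 to compound 4 (3.06 log units; beyond the scatter). No supporting data explain why these two rings differ.

The step changes both the halogen and its place on the ring, and the compounds shown cannot separate these two changes. From the compounds shown here alone, how a plain phenyl, or a ring carrying an amine or a carboxylic acid, would read stays open.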